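From Fluoro to Trifluoromethoxy: A Small Step Expected

This account rests on a few compounds, and the source may have more. Where it says the series, first, only, none or still open, it means among the compounds named here.

Of the compounds shown here, three have been measured in a functional assay on KB cells (Homo sapiens) for inhibition, read by MTT assay, with a stated time of 24 h, tested at 10 ug/mL; on this read-out higher numbers stand for more inhibition of growth at the one concentration tested and lower numbers for less inhibition of growth. Compound 1 (`O=C(CCCCC1CCSS1)Nc1ccc(OC(F)(F)F)cc1`) gives 8.49%, compound 2 (`O=C(CCCCC(S)CCS)Nc1ccc(Cl)cc1`) gives 18.2%, and compound 3 (`O=C(CCCCC(S)CCS)Nc1ccc(F)cc1`) gives 13.3%. Compound 3 therefore stands close to both of the others, and neither lies outside the scatter of its number.

Compound 4 (`O=C(CCCCC(S)CCS)Nc1ccc(OC(F)(F)F)cc1`) keeps the core of compound 3 and alters one group: trifluoromethoxy in place of fluoro on an aromatic carbon. In words, trifluoromethoxy takes the place of fluoro on an aromatic carbon.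

For the measured compounds named here, one measured step concerns this same place, where fluoro replaces chloro: a number 4.9 percentage points lower from compound 2 to compound 3 (within the scatter). That step is small, but it involves a much smaller exchange of groups than the one now proposed, so it offers only limited guidance. Compound 1 already carries trifluoromethoxy and gives 8.49%, but it has a different core, so it provides only a loose hint. Neither comparison points to a large change, so no shift beyond the scatter is expected in this assay. The expected step is a number 0.7 percentage points higher from compound 3 to compound 4 (within the scatter). For compound 4, the estimated value is 14%, with an expected range from 5% to 25%.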

Compound 4, percent growth inhibition at one concentration: 15%
Compound 4: the middle estimate sits 1 percentage points below what was measured; low and high end bracket the measured number.
By their numbers in this assay, from the lowest: compounds 1, 3, 4 and 2 (each within the scatter of the next).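

Within this assay, placing trifluoromethoxy, a group of 5 heavy atoms, on the aromatic carbon para to a large group gives a number 1.7 percentage points higher from compound 3 to compound 4 (within the scatter) when it replaces fluoro, and a number 3.2 percentage points lower from compound 2 to compound 4 (within the scatter) when it replaces chloro. On the shared core, therefore, the three groups tested at this position cannot be told apart, even though they differ considerably in size and one brings a hydrogen-bond acceptor that the fluoro group lacks. For the compounds shown here, compound 4 also provides the first comparison at the far end of the chain with trifluoromethoxy held constant: the open group in place of the one with a five-membered non-aromatic ring gives a number 6.5 percentage points higher from compound 1 to compound 4 (within the scatter) and no measurement here offers an explanation for any of these small steps.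

Going by these compounds, it remains open whether an amine or a carboxylic acid at the aromatic position would move the number beyond the usual scatter, or whether a longer chain on the amide carbonyl would do so. Each compound was also read at a single concentration, so these numbers cannot show whether the compounds would separate at other concentrations.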